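The compounds below may be only part of what the source reports. "The series", "measured", "known", "first", "only" and "open" are said of these compounds alone.

Values in a functional assay on HL-60 cells (Homo sapiens) for antiproliferative activity, read by MTT assay, with a stated time of 72 h; a higher number here means a weaker inhibitor, a lower number a stronger inhibitor:

- compound 1, `COc1cc(-n2ncnc2-c2ccc(OC(C)C)cc2)cc(OC)c1OC`: 700 nM
- compound 2, `COc1cc(-n2ncnc2-c2ccc(C)cc2)cc(OC)c1OC`: 90 nM
- compound 3, `CCOc1ccccc1-c1ncnn1-c1cc(OC)c(OC)c(OC)c1`: > 10000 nM

The value for compound 3 is a limit of this assay, not a number. Among the two numbers, compound 2 has the lowest; its nearest neighbour is compound 1, with a 7.8-fold lower number from compound 1 to compound 2 (0.89 log units; beyond the scatter), the change being methyl in place of isopropoxy on an aromatic carbon.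

Compound 4, `COc1cc(-n2ncnc2-c2ccc(Cl)c(Cl)c2)cc(OC)c1OC`, is not yet measured. It differs from compound 2 by 3,4-dichlorophenyl in place of 4-methylphenyl on an aromatic carbon. Among the measured compounds shown here, no measured step involves an exchange of this kind: the only measured step, a 7.8-fold lower number from compound 1 to compound 2 (0.89 log units; beyond the scatter), concerns an alkoxy group giving way to methyl on an aromatic carbon, and nothing measured shows how 3,4-dichlorophenyl compares with 4-methylphenyl. That step does show that changes on this aromatic carbon can move the number beyond the scatter in this assay, so a step of up to modest size in either direction is plausible for compound 4, with no direction favoured by the data.

Compound 4 is therefore expected at 150 nM, within 40 nM to 700 nM, which would mean a 1.7-fold higher number from compound 2 to compound 4 (0.22 log units; within the scatter).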

Compound 4, half-maximal inhibitory concentration: > 10000 nM
Compound 4: no number, only a limit; the forecaster's own chance of this, stated with the estimate: 5%; at least 66-fold (1.82 log units) between middle value and limit.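

In this assay, exchanging 4-methylphenyl for 3,4-dichlorophenyl on the aromatic carbon between two ring nitrogen atoms gives an at least 110-fold higher number from compound 2 to compound 4 (2.04 log units; beyond the scatter), a large step set against the modest 7.8-fold lower number from compound 1 to compound 2 (0.89 log units; beyond the scatter). Among the compounds shown here, the earlier step showed only that the number moves with a change on the phenyl group at this position; this one shows that a single exchange there can remove all measurable activity in this assay, even though the group that enters has one six-membered aromatic ring of carbon, as the group that leaves does. Compound 4 stands at a limit of the assay and not at a number, so the step gives only a lower bound on the change, and the size of the real loss stays unknown: the limit of > 10000 nM in this assay, at which 2 of the 4 values shown sit.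

The compounds shown do not separate the contributions of the two chlorine atoms, since neither 4-chlorophenyl nor 3-chlorophenyl stands among them. They also say nothing about how a fluorine, an amine or a hydroxyl group on this phenyl ring would compare with the methyl group of compound 2.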